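The source may report more compounds than this note shows. Statements on the series, on what has been measured and on what is new or still open speak of the compounds shown alone.

Compound 1 `O=c1[nH]c2ccc(Cl)cc2n1Cc1c(F)cccc1F` was examined in an ADME assay on MT4 cells (Homo sapiens) for cytotoxicity (a lower number here means that less compound is tolerated, a higher number that more compound is tolerated), where it gives only a limit, > 424000 nM. One of the three values shown here sits at that limit (the limit of > 424000 nM in this assay, at which 1 of the 3 values shown sits). Compound 3 `Cc1ccc2[nH]c(=O)n(Cc3c(F)cccc3F)c2c1` carries a methyl in place of chloro on an aromatic carbon, and in this assay compound 3 gives 236000 nM. That change produced an at least 1.7-fold lower number from compound 1 to compound 3 (0.25 log units; that floor lies within the scatter). Compound 2 `Cc1cc(C)cc(S(=O)(=O)n2c(=O)[nH]c3ccc(Cl)cc32)c1` has a different core; how it differs from compound 1 is not broken down here. In this assay compound 2 gives 39000 nM, the lowest of the two numbers, with compound 3 as its nearest neighbour.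

Compound 4 `Cc1cc(C)cc(S(=O)(=O)n2c(=O)[nH]c3ccc(C)cc32)c1` is not yet measured. It differs from compound 2 by the same change (methyl in place of chloro on an aromatic carbon), at a place described in identical words to the first instance. Since the step from compound 1 to compound 3 rests on a limit and lies within the usual scatter, compound 4 is expected to give a modest step, a 1.3-fold lower number from compound 2 to compound 4 (0.11 log units; within the scatter), beside that earlier one. The value estimated for compound 4 is 30000 nM, between 12000 nM and 80000 nM.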

Compound 4, half-maximal cytotoxic concentration: > 308000 nM
Compound 4 was reported as a limit; the forecaster's own chance of this, stated with the estimate: 5%; at least 10-fold (1.01 log units) between middle value and limit.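

In this assay compound 4 gives > 308000 nM, which is a limit of the assay and not a number. Putting methyl in place of chloro on an aromatic carbon thus gives an at least 7.8-fold higher number from compound 2 to compound 4 (0.89 log units; beyond the scatter), and the change does not carry from one core to the other as a fixed step: the same change on two cores in this assay, an at least 1.7-fold lower number (0.25 log units; that floor lies within the scatter) from compound 1 to compound 3 and an at least 7.8-fold higher number (0.89 log units; beyond the scatter) from compound 2 to compound 4, at least 14-fold (1.15 log units) apart, beyond the scatter of two such steps. From the compounds shown here alone, both steps rest on limits, so their true sizes remain unknown, and two pairs cannot show which feature of the cores sets them apart.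

The compounds shown carry only chloro or methyl at this place and only on these two cores, so it remains open how an amine, a carboxylic acid or a methoxy group there would read in this assay. It is also open whether other pairs on these cores would split in the same way, or whether this difference is confined to the chloro and methyl pairs shown here.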